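The compounds below may be only part of what the source reports. "The series", "measured", "known", "first", "only" and "open" are said of these compounds alone.

Of the compounds shown here, three built on one shared core have been measured, and a fourth awaits measurement. Compound 1 `COc1cc(-c2nnc(SCc3ccc(C)cc3)o2)ccc1O` gives 6210 nM in a functional assay on cells (T-cell, Mus musculus, strain BALB/c) for inhibition, read by MTT assay, with stated times of 24 h and 72 h; a higher number here means a weaker inhibitor, a lower number a stronger inhibitor. Compound 3 `COc1cc(-c2nnc(SCc3cccc(Cl)c3)o2)ccc1O` gives 8290 nM in this assay, and compound 2 `COc1cc(-c2nnc(SCc3cccc([N+](=O)[O-])c3)o2)ccc1O` gives 16000 nM in this assay. Compound 2 carries the highest of the three numbers; its nearest neighbour is compound 3, within the scatter, while its gap to compound 1 lies beyond the scatter. Compound 4 `COc1cc(-c2nnc(SCc3ccccc3)o2)ccc1O` is the unmeasured member, and it differs from compound 2 in one place: hydrogen in place of nitro on an aromatic carbon. Among the compounds with values here, two measured steps bear on this change. The step of a 1.9-fold lower number from compound 2 to compound 3 (0.29 log units; within the scatter) replaced the nitro group with another substituent, and the step of a 1.3-fold higher number from compound 1 to compound 3 (0.13 log units; within the scatter) exchanged one substituted benzyl group for another; neither moved the number beyond the scatter. Removing the nitro group altogether is therefore expected to produce a step of about a 1.9-fold lower number from compound 2 to compound 4 (0.27 log units; within the scatter), toward a lower number, though it may amount to no change beyond the scatter. Compound 4 is thus expected to give 8500 nM in this assay, with a range from 4000 nM to 18000 nM.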

Compound 4, half-maximal inhibitory concentration: 1250 nM
Beside the measured number, compound 4's estimate is 6.8-fold (0.83 log units) above it; the measured number lies below the stated range.
By their numbers in this assay, from the lowest: compound 4; then compounds 1, 3 and 2 (each within the scatter of the next, the first and the last beyond it).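

In this assay, within the data shown here, the earlier compounds, each with a substituent on the benzyl ring, had suggested that this ring tolerated exchange with little effect, but compound 4, with hydrogen there, stands apart from all of them. Removing the nitro group gives a 13-fold lower number from compound 2 to compound 4 (1.11 log units; beyond the scatter), and the same direction appears with hydrogen in place of chloro, a 6.6-fold lower number from compound 3 to compound 4 (0.82 log units; beyond the scatter), and in place of methyl, a 5.0-fold lower number from compound 1 to compound 4 (0.70 log units; beyond the scatter), so compound 4 is the strongest inhibitor of these four, and what mattered here was the presence of a substituent rather than the choice among these three. Nothing available explains this gap.

As far as these compounds go, whether a group as small as fluoro, or a hydroxyl or an amine, would keep the number near that of compound 4 remains open. So does whether hydrogen would give the same advantage with changes elsewhere on the shared core.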